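Melanocortin receptor 4 binding: amide side chain variation

A few compounds are considered here, and "the series" means these few. Any claim that something is new, unique, unknown or untested is made for them only; others in the source may bear on it.

Measured so far:
compound 1 `Cc1ccc(N2CCN(C(=O)[C@H](C)Cc3ccc(Cl)cc3F)CC2)c([C@@H](N)CC(C)C)c1` — 20 nM
compound 2 `CC(C)C[C@H](N)c1cc(C(F)(F)F)ccc1N1CCN(C(=O)CC(C)C(=O)c2ccc(Cl)cc2)CC1` — 1100 nM
compound 3 `CC(C)C[C@H](N)c1ccccc1N1CCN(C(=O)[C@H](C)Cc2ccc(Cl)cc2Cl)CC1` — 16 nM

In an assay on HEK293 cells for displacement of a labelled ligand from Melanocortin receptor 4 (Homo sapiens) (on this read-out lower numbers stand for stronger inhibition and higher numbers for weaker inhibition), compound 2 gives the highest number of the three, beyond the scatter from compound 1 and from compound 3, so compound 2 is the weakest binder here. Compound 4 `CC(C)C[C@H](N)c1cc(C(F)(F)F)ccc1N1CCN(C(=O)COc2ccc(Cl)cc2)CC1` keeps the core of compound 2 and differs in one place: 4-chlorophenoxy in place of 1-((4-chlorophenyl)carbonyl)ethyl on a saturated chain carbon bound to a carbonyl carbon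

Among the compounds with values here, no measured pair shows the effect of this change, so the direction rests on judgement. The shortened chain brings compound 4 closer in length to the side chains of compound 1 and compound 3, both far stronger; a modest improvement is expected, a 2.8-fold lower number from compound 2 to compound 4 (0.44 log units; beyond the scatter), though uncertain. Compound 4 is estimated at 400 nM, with a range from 100 nM to 2000 nM.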

Compound 4, inhibition constant: 2900 nM
Beside the measured number, compound 4's estimate is 7.3-fold (0.86 log units) below it; measured number outside the range, above it.
By their numbers in this assay, from the lowest: compounds 3 and 1 (each within the scatter of the next); then compound 2; then compound 4.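

In this assay, 4-chlorophenoxy in place of 1-((4-chlorophenyl)carbonyl)ethyl on a saturated chain carbon bound to a carbonyl carbon gives a 2.6-fold higher number from compound 2 to compound 4 (0.42 log units; beyond the scatter). This position therefore responds to the side chain, and this shortening moves binding the weaker way, a step beyond the scatter. Nothing available explains the change.

Still open, as far as these compounds go, is whether the ketone carbonyl, the ether oxygen or the chain length governs the step. A longer chain, or an amine at the same place, would test how far this trend extends.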